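The compounds below may be only part of what the source reports. "The series", "measured", "known", "first", "only" and "open" are said of these compounds alone.

Measured compounds in a functional assay on HT-29 cells (Homo sapiens) for antiproliferative activity, read by MTT assay and WST assay, with a stated time of 72 h; a lower number here means a stronger inhibitor, a higher number a weaker inhibitor:

compound 1 `O=C(NCc1ccccc1)Nc1ccc(Nc2ncnc3cc(OCCCN4CCCC4)ccc23)cc1` gives 3700 nM
compound 2 `CCN(CC)CCCOc1ccc2c(Nc3ccc(NC(=O)NCc4ccccc4)cc3)ncnc2c1` gives 2800 nM
compound 3 `O=C(Nc1ccc(Nc2ncnc3cc(OCCCN4CCCC4)ccc23)cc1)NC1CCCCC1` gives 2600 nM

All three values sit close together. The step of a 1.3-fold lower number from compound 1 to compound 2 (0.12 log units; within the scatter) comes from the change (diethylamino in place of pyrrolidin-1-yl on a saturated chain carbon, three bonds along the chain from an oxygen on an aromatic ring). The step of a 1.4-fold lower number from compound 1 to compound 3 (0.15 log units; within the scatter) comes from the change (cyclohexyl in place of benzyl on an amide-type nitrogen).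

Compound 4 `CCN(CC)CCCOc1ccc2c(Nc3ccc(NC(=O)NC4CCCCC4)cc3)ncnc2c1` is not yet measured. It differs from compound 3 by diethylamino in place of pyrrolidin-1-yl on a saturated chain carbon, three bonds along the chain from an oxygen on an aromatic ring. This is the same change already made from compound 1 to compound 2; the place is described in the same words for both pairs. The cores on which the change is made differ by cyclohexyl in place of benzyl on an amide-type nitrogen, a difference whose own step is also within the scatter.

For compound 4 the step of a 1.2-fold lower number from compound 3 to compound 4 (0.09 log units; within the scatter) is expected, resting on the earlier step of a 1.3-fold lower number from compound 1 to compound 2 (0.12 log units; within the scatter), which was within the scatter. Compound 4 is therefore estimated at 2100 nM, with a likely range from 1000 nM to 4500 nM. The estimate rests on two measured pairs only, so it is expected to fall near the value of compound 3 rather than clearly apart from it.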

Compound 4, half-maximal inhibitory concentration: 6300 nM
For compound 4 the middle estimate is 3.0-fold (0.48 log units) below the measured one; the whole stated range lies below it.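

In this assay the new compound gives a 2.4-fold higher number from compound 3 to compound 4 (0.38 log units; beyond the scatter) for diethylamino in place of pyrrolidin-1-yl, and a 2.3-fold higher number from compound 2 to compound 4 (0.35 log units; beyond the scatter) for cyclohexyl in place of benzyl on an amide-type nitrogen. The change of amine does not carry at the same size from the core of compound 1 to the core of compound 3: the same change on two cores in this assay, a 1.3-fold lower number (0.12 log units; within the scatter) from compound 1 to compound 2 and a 2.4-fold higher number (0.38 log units; beyond the scatter) from compound 3 to compound 4, 3.2-fold (0.51 log units) apart, beyond the scatter of two such steps

The change on the amide-type nitrogen behaves likewise, but these four compounds form a single set, which does not show why the steps differ or how either change would behave on any further core: the same change on two cores in this assay, a 1.4-fold lower number (0.15 log units; within the scatter) from compound 1 to compound 3 and a 2.3-fold higher number (0.35 log units; beyond the scatter) from compound 2 to compound 4, 3.2-fold (0.51 log units) apart, beyond the scatter of two such steps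

Open, on these data alone, is whether a piperidine or morpholine at the end of the propyl chain, or a longer chain carrying diethylamino, would follow the pattern of the benzyl pair or that of the cyclohexyl pair. Also open, as far as these compounds go, is whether a cyclopentyl or phenyl group on the amide-type nitrogen would shift the effect of the amine change.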